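A few compounds are considered here, and "the series" means these few. Any claim that something is new, unique, unknown or untested is made for them only; others in the source may bear on it.

Compound 1 `CC(C)C(=O)OCOC(=O)C1=C(S[C@@H]2CN[C@H](C(=O)Nc3cccc(C(=O)O)c3)C2)[C@H](C)[C@@H]2[C@@H]([C@@H](C)O)C(=O)N12` was examined in an ADME assay for metabolic stability, read by LC-MS, with a stated time of 3 h, at pH 6.5, tested at 50 uM; a higher number here means that more of the compound is left, a lower number that less of the compound is left. In this assay compound 1 gives > 95%, which is a limit of the assay rather than a measured number. Compound 2 `CC(C)C(=O)OCOC(=O)C1=C(S[C@@H]2CN[C@H](C(=O)Nc3cccc(C(=O)OCOC(=O)C(C)C)c3)C2)[C@H](C)[C@@H]2[C@@H]([C@@H](C)O)C(=O)N12` differs from compound 1 at a single place. In this assay compound 2 gives > 95%, again only a limit. Compound 3 `CC(C)c1oc(=O)oc1COC(=O)C1=C(S[C@@H]2CN[C@H](C(=O)Nc3cccc(C(=O)OCc4oc(=O)oc4C(C)C)c3)C2)[C@H](C)[C@@H]2[C@@H]([C@@H](C)O)C(=O)N12` completes the measured set. In this assay compound 3 gives > 95%, once more a limit. The step that the two limits leave unreadable from compound 1 to compound 2 therefore cannot be read, since both ends sit at the same limit. Compound 1 thus stands at the top edge of what the assay can report, and the two other measured compounds stand there with it, as the summary the limit of > 95% in this assay, at which 3 of the 3 values shown sit, shows.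

Compound 4 `CC(C)OC(=O)OCOC(=O)C1=C(S[C@@H]2CN[C@H](C(=O)Nc3cccc(C(=O)O)c3)C2)[C@H](C)[C@@H]2[C@@H]([C@@H](C)O)C(=O)N12` has not yet been measured. Its difference from compound 1 is isopropoxy in place of isopropyl on a carbonyl carbon. Within the data shown here, the only measured step, the one with an unreadable size, gives no guide to how large a change of this kind might be, so no direction can be drawn from it. Because every measured value sits at the limit (the limit of > 95% in this assay, at which 3 of the 3 values shown sit), compound 4 is expected to stay there as well, with an expected step that the limit leaves unreadable from compound 1 to compound 4. The estimated value for compound 4 is 96%, expected to lie between 86% and 100%.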

Compound 4, percent of the compound remaining: > 95%
Compound 4: only a limit was reported (the forecaster's own chance of this, stated with the estimate: 80%); the middle value is on the limit's open side.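

In this assay compound 4 gives > 95%, which is a limit of the assay and not a number. Among these compounds, compound 1 also carries only a limit, so no step between compound 1 and compound 4 can be read. The compounds shown leave open whether isopropoxy and isopropyl differ at all in this read-out, because all the values share one limit: the limit of > 95% in this assay, at which 4 of the 4 values shown sit.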